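The compounds below may be only part of what the source reports. "The series", "measured", "known", "first", "only" and "open" are said of these compounds alone.

Compound 1 `Cc1cc(C(=O)O)c(C)n1-c1cccc(F)c1` gives 1500 nM in an assay on cells for inhibition of Palmitoleoyl-protein carboxylesterase NOTUM variant C330S (Homo sapiens), read by fluorescence, with a stated time of 40 min (on this read-out higher numbers stand for weaker inhibition and lower numbers for stronger inhibition), and compound 2 `Cc1cc(C(=O)O)c(C)n1-c1cccc(C(F)(F)F)c1` gives 1500 nM in this assay; the step of no change at the digits printed from compound 2 to compound 1 (within the scatter) is the change (fluoro in place of trifluoromethyl on an aromatic carbon). Compound 3 `O=C(O)C1CCN(c2ccc(C(F)(F)F)cc2)C1` is built on a different core, and how its core differs from that of compound 2 is not broken down here; in this assay compound 3 gives 50000 nM, the highest number of the three. Compound 4 `O=C(O)C1CCN(c2ccc(F)cc2)C1` carries the change (fluoro in place of trifluoromethyl on an aromatic carbon), the same kind of change as that from compound 2 to compound 1, though here the fluoro sits para to a group of 8 heavy atoms rather than meta to a large group. Because the measured step of no change at the digits printed from compound 2 to compound 1 (within the scatter) was flat, the step of no change at the digits printed from compound 3 to compound 4 (within the scatter) is expected to be small as well. Compound 4 is therefore estimated at 50000 nM, with 20000 nM to 120000 nM as the expected range.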

Compound 4, half-maximal inhibitory concentration: 15000 nM
For compound 4 the middle estimate is 3.3-fold (0.52 log units) above the measured one, outside the stated range (below it).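

The change from trifluoromethyl to fluoro did not carry over unchanged from one core to the other in this assay: the same change on two cores in this assay, no change at the digits printed (within the scatter) from compound 2 to compound 1 and a 3.3-fold lower number (0.52 log units; beyond the scatter) from compound 3 to compound 4, 3.3-fold (0.52 log units) apart, beyond the scatter of two such steps. On the core of compound 3 the change gives a 3.3-fold lower number from compound 3 to compound 4 (0.52 log units; beyond the scatter), whereas on the core of compound 2 it gives no change at the digits printed from compound 2 to compound 1 (within the scatter), so the flat step on one core did not predict the step on the other. With one pair on each core, and the group placed differently on the two, these data cannot separate the effect of the core from that of the position, and they do not show why the steps differ.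

The compounds shown leave open whether a nitrile or an amine in place of the fluoro would give steps that also differ between the two cores.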